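The source may report more compounds than this note shows. Statements on the series, on what has been measured and on what is new or still open speak of the compounds shown alone.

In an ADME assay on MRC5 cells (Homo sapiens) for cytotoxicity, read by fluorescence, with a stated time of 72 h (a higher number here means a weaker inhibitor, a lower number a stronger inhibitor), compound 1 (`CC1(COc2ccc(OC(F)(F)F)cc2)Cn2ccnc2O1`) gives > 64000 nM as a limit, not a number. Compound 2 (`CC1(COc2ccc(OC(F)(F)F)cc2)Cn2cc(C=O)nc2O1`) gives > 64000 nM and this too is a limit. Compound 2 therefore has no number of its own, and the reading shared with compound 1 is the limit of > 64000 nM in this assay, at which 2 of the 2 values shown sit, and nothing more. Going by the values given here, the one measured step is a step that the two limits leave unreadable from compound 1 to compound 2 and offers no size to carry over.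

Among the compounds with values here, the change to compound 3 (`CSc1cn2c(n1)OC(C)(COc1ccc(OC(F)(F)F)cc1)C2`) is methylsulfanyl in place of formyl on an aromatic carbon, counted as methylsulfanyl in place of formyl on an aromatic carbon and covered by no measured step. For compound 3 no step beyond the scatter is expected in this assay in either direction because the limit of > 64000 nM in this assay, at which 2 of the 2 values shown sit, is all the series offers. The estimated step is a number no higher from compound 2 to compound 3 (the limit leaves the size open) and remains an expectation only. Compound 3 is expected at 64000 nM within 30000 nM to 100000 nM.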

Compound 3, half-maximal inhibitory concentration: 38000 nM
Estimate against measurement, compound 3: 1.7-fold (0.23 log units) above, and the stated range covers the measured number.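

In this assay, going by these compounds alone, compound 3 gives 38000 nM, the first reading that is a number and not a limit, so a change on this aromatic carbon of the five-membered aromatic ring can bring the reading inside the measurable range. Methylsulfanyl in place of formyl gives an at least 1.6-fold lower number from compound 2 to compound 3 (0.22 log units; that floor lies within the scatter), and methylsulfanyl in place of hydrogen gives an at least 1.6-fold lower number from compound 1 to compound 3 (0.22 log units; that floor lies within the scatter). Both steps are floors measured against limits, and the rest of the series still reads only as a limit: the limit of > 64000 nM in this assay, at which 2 of the 3 values shown sit.

The compounds shown leave open how a methoxy group, an amine or a longer alkylsulfanyl chain on this carbon would read in this assay. They also leave open whether the sulfur of methylsulfanyl is what sets compound 3 apart from the two limits.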